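Benzamide to phenylethenyl amide on a fixed chain

The source may hold more compounds than are shown below. What is called first, only, known or untested is meant among the compounds shown, and "the series" means these compounds.

Compound 1 `CCCCCCCCCCCCNC(=O)[C@@H](NC(=O)c1ccccc1)[C@@H](C)O` gives 36600 nM in a functional assay on MCF7 cells (Homo sapiens) for cytotoxicity, read by MTT assay, with a stated time of 48 h; on this read-out lower numbers stand for stronger inhibition and higher numbers for weaker inhibition.
Compound 2 `CCCCCCCCCCCCCCNC(=O)[C@@H](NC(=O)c1ccccc1)[C@@H](C)O` gives 24800 nM in this assay.
Compound 3 `CCCCCCCCCCCCCCCCCCNC(=O)[C@@H](NC(=O)c1ccccc1)[C@@H](C)O` gives 31800 nM in this assay.

The three measured compounds share one core and differ only in how long the saturated chain on the amide nitrogen is. The steps between them are small: a 1.5-fold lower number from compound 1 to compound 2 (0.17 log units; within the scatter), a 1.2-fold lower number from compound 1 to compound 3 (0.06 log units; within the scatter) and a 1.3-fold higher number from compound 2 to compound 3 (0.11 log units; within the scatter). None of them goes beyond the scatter, so within this set the length of the chain does not shift the read-out in a way that can be trusted. Compound 3 stands second highest of the three numbers, nearest to compound 1 and furthest from compound 2, both gaps within the scatter.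

Compound 4 `CCCCCCCCCCCCCCCCCCNC(=O)[C@@H](NC(=O)/C=C/c1ccccc1)[C@@H](C)O` keeps the chain of compound 3 and changes the other amide instead: 2-phenylethenyl in place of phenyl on a carbonyl carbon. Within the data shown here, none of the measured steps touches this part of the molecule; all of them concern the chain, and they were all within the scatter. They therefore say nothing about the direction of this change, and the expectation for the step of a 1.1-fold lower number from compound 3 to compound 4 (0.03 log units; within the scatter) is set at no change with a wide range to cover the untested acyl group. Compound 4 is estimated at 30000 nM, within 9000 nM to 100000 nM.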

Compound 4, half-maximal inhibitory concentration: 39200 nM
For compound 4 the middle estimate is 1.3-fold (0.12 log units) below the measured one; the range from low to high includes it.
By their numbers in this assay, from the lowest: compounds 2, 3, 1 and 4 (each within the scatter of the next).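

Among these compounds, until this result, every measured step concerned the saturated chain, so the other amide had no reading of its own. The step of a 1.2-fold higher number from compound 3 to compound 4 (0.09 log units; within the scatter) in this assay provides the first one: with the long chain of compound 3 held fixed, 2-phenylethenyl in place of phenyl on a carbonyl carbon brings in a double bond outside aromatic rings and a larger group, yet the read-out does not shift in a way that can be trusted. No measurement available here bears on why the read-out responds in this way.

This single pair cannot show whether the same replacement would also stay within the scatter on the shorter chains of compound 1 and compound 2. Also open, on these data alone, is how the read-out would respond to other groups on this carbonyl carbon, such as saturated 2-phenylethyl, which lacks the double bond, or a phenyl ring carrying an amine or a carboxylic acid.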